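Adding a Methyl to a Weakly Active Anilino Compound

The source may report more compounds than this note shows. Statements on the series, on what has been measured and on what is new or still open speak of the compounds shown alone.

Compound 1 `CC(C)c1ccc(-c2nc(SCc3cn(CC(=O)NC(=O)Nc4ccccn4)nn3)nc(Nc3cccc([N+](=O)[O-])c3)c2C#N)cc1` gives 31300 nM in a functional assay on ECa-109 cells (Homo sapiens) for inhibition, read by MTT assay, with a stated time of 72 h; on this read-out higher numbers stand for weaker inhibition and lower numbers for stronger inhibition. Compound 2 `CC(C)c1ccc(-c2nc(SCc3cn(CC(=O)NC(=O)Nc4ccccn4)nn3)nc(Nc3ccccc3)c2C#N)cc1` reaches only a limit in this assay, > 64000 nM. Within the data shown here, the single measured step, an at least 2.0-fold higher number from compound 1 to compound 2 (0.31 log units; beyond the scatter), places compound 2 at the limit of > 64000 nM in this assay, at which 1 of the 2 values shown sits. Compound 3 `Cc1ccccc1Nc1nc(SCc2cn(CC(=O)NC(=O)Nc3ccccn3)nn2)nc(-c2ccc(C(C)C)cc2)c1C#N` differs from compound 2 by methyl in place of hydrogen on an aromatic carbon. Among the measured compounds shown here, no measured step concerns a methyl entering in place of hydrogen, so the step that the limit leaves unreadable from compound 2 to compound 3 is expected to stay within the scatter. Compound 3 is therefore estimated at 90000 nM, between 40000 nM and 200000 nM, most probably reported again as a limit.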

Compound 3, half-maximal inhibitory concentration: 7230 nM
Estimate against measurement, compound 3: 12-fold (1.10 log units) above; the measured number lies below the stated range.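

Methyl on the aromatic carbon ortho to a large group gives an at least 8.8-fold lower number from compound 2 to compound 3 (0.94 log units; beyond the scatter), so this ring responds to a small carbon group as well as to nitro. The 2-methylphenyl also improves on the 3-nitrophenyl, with a 4.3-fold lower number from compound 1 to compound 3 (0.64 log units; beyond the scatter). Compound 2 stands only as a limit, so the first of these steps has no fixed size: the limit of > 64000 nM in this assay, at which 1 of the 3 values shown sits.

From the compounds shown here alone, what ethyl, methoxy or chlorine would give at this same place remains open. Also open, going by these compounds, is whether a methyl elsewhere on the ring would give a similar result.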